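Removing the isopropyl from the cyclic urea

This account rests on a few compounds, and the source may have more. Where it says the series, first, only, none or still open, it means among the compounds named here.

Compound 1 `O=C1NCCN1CCN1CCC(c2cn(-c3ccc(F)cc3)c3cc(Cl)ccc23)CC1`: 9.6 nM
Compound 2 `CC(C)N1CCN(CCN2CCC(c3cn(-c4ccc(F)cc4)c4cc(F)ccc34)CC2)C1=O`: 13 nM

In an assay on cell membranes for displacement of a labelled ligand from Adrenergic receptor alpha-1 (Rattus norvegicus) (a higher number here means a weaker inhibitor, a lower number a stronger inhibitor), compound 2 gives the higher of the two numbers, and compound 1 stands within the scatter of it. Compound 3 `O=C1NCCN1CCN1CCC(c2cn(-c3ccc(F)cc3)c3cc(F)ccc23)CC1` has not yet been tested. It differs from compound 2 by hydrogen in place of isopropyl on an amide-type nitrogen in a ring. Within the data shown here, no measured pair shows this change directly, so the step from compound 2 to compound 3 is expected to stay within the scatter, with no clear direction. Compound 1, which carries the same hydrogen on the ring nitrogen, gives 9.6 nM, which supports an estimate of 11 nM for compound 3, between 4 nM and 30 nM, a step of a 1.2-fold lower number from compound 2 to compound 3 (0.07 log units; within the scatter) that is expected to be small.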

Compound 3, half-maximal inhibitory concentration: 2.2 nM
Compound 3: middle estimate off by 5.0-fold (0.70 log units), on the high side, and the stated range ends above it.
By their numbers in this assay, from the lowest: compound 3; then compounds 1 and 2 (each within the scatter of the next).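

In this assay, hydrogen in place of isopropyl on the amide-type nitrogen gives a 5.9-fold lower number from compound 2 to compound 3 (0.77 log units; beyond the scatter), so this position responds to the change when the rest of the structure stays fixed. Fluoro in place of chloro on the aromatic carbon, with that hydrogen kept, gives a 4.4-fold lower number from compound 1 to compound 3 (0.64 log units; beyond the scatter), so the ring nitrogen is not the only place that matters. Nothing available accounts for either step. Still open, going by these compounds, is whether a methyl or a cyclopropyl on that nitrogen would give a number nearer compound 3 or compound 2, and whether the fluoro-for-chloro step would hold with isopropyl in place.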